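Swapping a ring hydrogen for chlorine on a chalcone

The source may hold more compounds than are shown below. What is called first, only, known or untested is meant among the compounds shown, and "the series" means these compounds.

Three compounds share a core and differ only in the ring at the far end of the double-bonded chain. Compound 1 `COc1cc(OC)c(C(=O)/C=C/c2ccccc2SC)c(OC)c1` gives 16% in a functional assay on MDA-MB-231 cells (Homo sapiens), read by fluorescence and BrdU incorporation, with a stated time of 48 h, tested at 25 uM (a lower number here means a stronger effect, a higher number a weaker effect of the compound at the concentration tested), compound 2 `COc1cccc(/C=C/C(=O)c2c(OC)cc(OC)cc2OC)c1` gives 12%, and compound 3 `COc1cc(OC)c(C(=O)/C=C/c2ccccc2)c(OC)c1` gives 23%. Compound 3 has the highest of the three numbers: the step of a number 7 percentage points higher from compound 1 to compound 3 (within the scatter) stays within the scatter, while the step of a number 11 percentage points higher from compound 2 to compound 3 (beyond the scatter) goes beyond it, so compound 3 shows a weaker effect than compound 2 but cannot be separated from compound 1.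

Compound 4 `COc1cc(OC)c(C(=O)/C=C/c2ccc(Cl)cc2)c(OC)c1` is not yet measured. It differs from compound 3 by chloro in place of hydrogen on an aromatic carbon, with the chloro placed para to a large group on the six-membered aromatic ring of carbon only. Going by the values given here, no measured step puts chloro on this ring; the two steps that reach compound 3 remove a methylsulfanyl or a methoxy group from other places on it, and those were a number 7 percentage points higher from compound 1 to compound 3 (within the scatter) and a number 11 percentage points higher from compound 2 to compound 3 (beyond the scatter). Substituents on this ring therefore move the number only modestly or not at all. For compound 4 a small step, if any, is expected: a number 5 percentage points lower from compound 3 to compound 4 (within the scatter). Compound 4 is estimated at 18%, within a range of 5% to 35%.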

Compound 4, a percentage reported as activity, at one concentration (the size of the read-out at that concentration, not a potency): 2.1%
Compound 4: the middle estimate sits 15.9 percentage points above what was measured; the whole stated range lies above it.
By their numbers in this assay, from the lowest: compounds 4, 2, 1 and 3 (each within the scatter of the next, the first and the last beyond it).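

Chloro in place of hydrogen, on an aromatic carbon para to a large group, produces the largest step seen so far among these compounds in this assay: a number 20.9 percentage points lower from compound 3 to compound 4 (beyond the scatter). The earlier steps shown here involved a methylsulfanyl or methoxy group placed elsewhere on this ring and did not show that a single added chlorine atom at this place could move the number this far. The comparisons with the other substituted rings give a split result, with a number 13.9 percentage points lower from compound 1 to compound 4 (beyond the scatter) for the change from 2-(methylsulfanyl)phenyl to 4-chlorophenyl, but a number 9.9 percentage points lower from compound 2 to compound 4 (within the scatter) for the change from 3-methoxyphenyl, so 4-chlorophenyl stands apart from phenyl and 2-(methylsulfanyl)phenyl but cannot be separated from 3-methoxyphenyl.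

No measurement at hand accounts for what the chlorine does here. The compounds shown leave open whether fluoro, bromo, methyl or an amine on the same aromatic carbon would give a similar number, and whether chloro on another carbon of this ring would do the same.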